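Notes on the aryl-amine swap from compound 2 to compound 4

The source may report more compounds than this note shows. Statements on the series, on what has been measured and on what is new or still open speak of the compounds shown alone.

Three compounds of the series have numbers in a functional assay on NCI-H520 cells (Homo sapiens) for inhibition, read by MTT assay, with a stated time of 48 h, tested at 10 uM; on this read-out lower numbers stand for less inhibition and higher numbers for more inhibition at the one concentration tested (going by the name of the read-out). Compound 1 `COc1ccc(F)cc1Nc1cc(NC(=O)Nc2c(Cl)cccc2Cl)ncn1` gives 38.1%. Compound 2 `COc1cc(NC(=O)Nc2cc(Nc3cc(F)ccc3OC)ncn2)cc(OC)c1` gives 38%, the lowest of the three numbers, though the gap to compound 1 is within the scatter, a number 0.1 percentage points lower from compound 1 to compound 2 (within the scatter). Compound 3 `COc1cc(NC(=O)Nc2cc(Nc3cc(C(F)(F)F)ccc3OC)ncn2)cc(OC)c1` gives 63%, and the step of a number 25 percentage points higher from compound 2 to compound 3 (beyond the scatter) is the only one beyond the scatter.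

Compound 4 `COc1cc(NC(=O)Nc2cc(Nc3ccc(OC)c(C)c3)ncn2)cc(OC)c1` is not yet measured. It differs from compound 2 at one place: 4-methoxy-3-methylphenyl in place of 5-fluoro-2-methoxyphenyl on a nitrogen on an aromatic ring. Among the compounds with values here, no measured step makes this exchange. The step from compound 1 to compound 2 sits on the amide-type nitrogen, away from the ring being replaced, and was flat. The step from compound 2 to compound 3 alters the same ring but only trades fluoro for trifluoromethyl on an aromatic carbon; it was modest. The whole-ring exchange has no parallel in the series, so no direction can be read from it. For compound 4 the expected step of a number 2 percentage points higher from compound 2 to compound 4 (within the scatter) is therefore small, within the scatter, though a wide range is carried. The estimate for compound 4 in this assay is 40%, with a range from 20% to 65%.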

Compound 4, a percentage reported as inhibition, at one concentration (the size of the read-out at that concentration, not a potency): 13.5%
Estimate against measurement, compound 4: 26.5 percentage points above; the whole stated range lies above it.
By their numbers in this assay, from the lowest: compound 4; then compounds 2 and 1 (each within the scatter of the next); then compound 3.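

In this assay, within the data shown here, the whole-ring exchange on a nitrogen on an aromatic ring is not neutral: 4-methoxy-3-methylphenyl in place of 5-fluoro-2-methoxyphenyl gives a number 24.5 percentage points lower from compound 2 to compound 4 (beyond the scatter) and is the only step downward beyond the scatter. Set against a number 25 percentage points higher from compound 2 to compound 3 (beyond the scatter) in the other direction, it shows that the aryl group on this nitrogen can move the number either way, whereas a number 0.1 percentage points lower from compound 1 to compound 2 (within the scatter) on the amide-type nitrogen stays flat. Nothing at hand gives a reason for the lower number of compound 4.

The exchange alters the fluoro, the methyl and the place of the methoxy at once, so the compounds shown do not separate their shares in the step. Also open, on these data alone, is how this ring behaves with an amine or a carboxylic acid in place of the methyl of compound 4.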